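A few compounds are considered here, and "the series" means these few. Any claim that something is new, unique, unknown or untested is made for them only; others in the source may bear on it.

Compound 1 `O=C(O)CNC(=O)c1c(O)c2c(n(Cc3ccc(C(F)(F)F)cc3)c1=O)COC2` gives 3.6 nM in an assay on Sf9 cells for inhibition of prolyl hydroxylase EGLN2 (Homo sapiens), read by TR-FRET, with stated times of 30 min and 2 h; a lower number here means a stronger inhibitor, a higher number a weaker inhibitor. Compound 2 `O=C(O)CNC(=O)c1c(O)c2c(n(Cc3ccc(Cl)cc3)c1=O)COC2` gives 2.1 nM in this assay, and compound 3 `O=C(O)CNC(=O)c1c(O)c2c(n(Cc3ccc(OC(F)(F)F)cc3)c1=O)COC2` gives 2.4 nM. Compound 2 holds the lowest of these three numbers, though the steps of a 1.7-fold lower number from compound 1 to compound 2 (0.23 log units; within the scatter) and a 1.1-fold higher number from compound 2 to compound 3 (0.06 log units; within the scatter) both lie within the scatter, as does a 1.5-fold lower number from compound 1 to compound 3 (0.18 log units; within the scatter). Compound 4 `O=C(O)CNC(=O)c1c(O)c2c(n(Cc3ccc(F)cc3F)c1=O)COC2` differs from compound 2 in one place: 2,4-difluorophenyl in place of 4-chlorophenyl on a saturated chain carbon bound to an aromatic nitrogen. The three measured steps all exchange one group on that aromatic ring and none moved the number beyond the scatter, so no step beyond the scatter is expected in this assay either; the expected step is a 1.4-fold higher number from compound 2 to compound 4 (0.15 log units; within the scatter). Compound 4 is therefore estimated at 3 nM, with a range from 1.2 nM to 8 nM.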

Compound 4, half-maximal inhibitory concentration: 2.2 nM
Compound 4: the middle estimate sits 1.4-fold (0.13 log units) above what was measured; the measured number falls inside the stated range.
By their numbers in this assay, from the lowest: compounds 2, 4, 3 and 1 (each within the scatter of the next).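

The earlier steps shown here each exchanged one group on the aromatic ring, whereas here the whole 4-chlorophenyl gives way to 2,4-difluorophenyl on the saturated chain carbon, and this assay shows a 1.0-fold higher number from compound 2 to compound 4 (0.02 log units; within the scatter). The number therefore stays within the scatter even when one chlorine is replaced by two fluorines on that ring. Nothing available explains this result. The compounds shown leave open whether the number would hold with an amine or a carboxylic acid on this ring. They also leave open the effect of a pyridine ring or a longer chain at this place.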